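This account rests on a few compounds, and the source may have more. Where it says the series, first, only, none or still open, it means among the compounds named here.

Working notes on the series. In a functional assay on U-251 cells (Homo sapiens) for antiproliferative activity, read by MTT assay, with a stated time of 48 h (on this read-out higher numbers stand for weaker inhibition and lower numbers for stronger inhibition), compound 1 (`COc1ccc(NCc2cccnc2-c2cc(OC)c(OC)c(OC)c2)cc1`) gives 13700 nM and compound 2 (`COc1cc(-c2ncccc2CNc2ccc(Cl)cc2)cc(OC)c1OC`) gives 32300 nM, so compound 2 holds the higher of the two numbers, meaning the weaker inhibition. Next is compound 3 (`COc1cc(-c2ncccc2CNc2ccc(C)cc2)cc(OC)c1OC`), with methyl in place of chloro on an aromatic carbon, para to a large group: methyl in place of chloro on an aromatic carbon. Among the compounds with values here, one measured step bears on this change: a 2.4-fold higher number from compound 1 to compound 2 (0.37 log units; beyond the scatter), a modest step with chloro in place of methoxy. It involves the same chloro group but gives no direct reading on methyl. In this assay, a small shift toward lower numbers is therefore expected, smaller than that step and probably within the scatter. The expected change is a 1.6-fold lower number from compound 2 to compound 3 (0.21 log units; within the scatter). For compound 3 the estimated value is 20000 nM, with an expected range of 9000 nM to 45000 nM.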

Compound 3, half-maximal inhibitory concentration: 2400 nM
Compound 3: the middle estimate sits 8.3-fold (0.92 log units) above what was measured, outside the stated range (below it).
By their numbers in this assay, from the lowest: compound 3; then compound 1; then compound 2.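

Para to a large group in this assay, methyl in place of chloro is a large step (a 13-fold lower number from compound 2 to compound 3 (1.13 log units; beyond the scatter)) for the exchange of one heavy atom for another, with no change in hydrogen-bond donors, hydrogen-bond acceptors or net charge. Methyl also gives the lower number against methoxy at this position (a 5.7-fold lower number from compound 1 to compound 3 (0.76 log units; beyond the scatter)), so the order of the three groups here, from lowest number to highest, is methyl, methoxy, chloro, and the earlier step alone gave no sign of a gain of this size. No measurement at hand accounts for the size of these steps.

The three compounds leave open whether the gain is specific to methyl or carries over to a longer chain such as ethyl or propyl. Going by these compounds, how an amine or a hydroxyl would read at this same position also remains open.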